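The source may report more compounds than this note shows. Statements on the series, on what has been measured and on what is new or still open speak of the compounds shown alone.

Of the compounds shown here, three have been measured in a functional assay on MCF7 cells (Homo sapiens) for antiproliferative activity, read by MTT assay, with a stated time of 6 days; a lower number here means a stronger inhibitor, a higher number a weaker inhibitor. Compound 1 `CC(=O)O[C@@H]1C=CC(=O)O[C@@H]1[C@@H](COC(=O)c1ccc([N+](=O)[O-])cc1)OC(C)=O` gives 5320 nM, compound 2 `O=C1C=C[C@@H](OCc2ccccc2)[C@@H]([C@@H](COC(=O)/C=C/c2ccccc2)OCc2ccccc2)O1` gives 2570 nM, and compound 3 `CC(=O)O[C@@H]1C=CC(=O)O[C@@H]1[C@@H](COC(=O)/C=C/c1ccc([N+](=O)[O-])cc1)OC(C)=O` gives 1400 nM. Among these, compound 2 holds the second highest number of the three: its gap to compound 3 lies within the usual scatter, while its gap to compound 1 lies beyond it, so compound 1 is the weaker inhibitor of that pair.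

Compound 4 `CC(=O)OC[C@@H](OCc1ccccc1)[C@H]1OC(=O)C=C[C@H]1OCc1ccccc1` has not yet been measured. It differs from compound 2 in one place: methyl in place of 2-phenylethenyl on a carbonyl carbon. Among the measured compounds shown here, no directly comparable step between measured compounds exists here, so the expectation rests on the values themselves. Compound 1 and compound 3 show that a shorter ester group on a related core went along with a higher number, and on that basis a moderate move toward a weaker inhibitor is expected for compound 4.

Compound 4 is therefore expected to give 6000 nM, with a likely range from 2500 nM to 15000 nM. That expectation corresponds to a step of a 2.3-fold higher number from compound 2 to compound 4 (0.37 log units; beyond the scatter).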

Compound 4, half-maximal inhibitory concentration: 18900 nM
Beside the measured number, compound 4's estimate is 3.2-fold (0.50 log units) below it; measured number above the stated range.
By their numbers in this assay, from the lowest: compounds 3 and 2 (each within the scatter of the next); then compound 1; then compound 4.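

In this assay, among the compounds shown here, putting methyl in place of 2-phenylethenyl on this carbonyl carbon gives a 7.4-fold higher number from compound 2 to compound 4 (0.87 log units; beyond the scatter), the first direct comparison here between two compounds that differ in one place. With the rest of the structure unchanged, this single change takes the compound to a clearly weaker level, so the group on this carbonyl carbon has a real bearing on the number in this assay. No measurement shown here explains the size of this step.

Both the aromatic ring and the double bond leave together in this change, so the pair cannot show which of them matters, or whether both do. From the compounds shown here alone, a 2-phenylethyl group would keep the ring without the double bond, and where it or a longer carbon chain would fall remains open.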